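This account rests on a few compounds, and the source may have more. Where it says the series, first, only, none or still open, it means among the compounds named here.

Compound 1 `CCCCC#Cc1c(C)[nH]c2ccc(Cl)cc2c1=O` gives > 36300 nM in an ADME assay on J774 cells (Mus musculus) for cytotoxicity; on this read-out higher numbers stand for an effect only at larger amounts of compound and lower numbers for an effect already at smaller amounts; this value is a limit of the assay, not a number.
Compound 2 `COc1cc2[nH]c(C)c(C)c(=O)c2cc1Cl` gives 12200 nM in this assay.

Among the compounds with values here, of the two values shown, compound 2 carries the only number; the other value is a limit, so compound 2 simply stands as the one measured point on this read-out.

Compound 3 `CCCCC#Cc1c(C)[nH]c2cc(OC)c(Cl)cc2c1=O` has not been measured. It differs from compound 2 in one place hex-1-yn-1-yl in place of methyl on an aromatic carbon: the hex-1-yn-1-yl chain of six carbons takes the position held by a methyl in compound 2, while the methoxy and chlorine on the shared core stay in place.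

Within the data shown here, no measured pair differs in exactly this way, so the size of the step is open. Compound 1, which also carries the hex-1-yn-1-yl chain, sits at the limit, as noted in the limit of > 36300 nM in this assay, at which 1 of the 2 values shown sits. From that, the step from compound 2 to compound 3 is expected to go toward a larger number, with a 2.5-fold higher number from compound 2 to compound 3 (0.39 log units; beyond the scatter) as the expected change. Compound 3 is estimated at 30000 nM, within a range from 12000 nM to 70000 nM, and it may well return only a limit.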

Compound 3, half-maximal effective concentration: 15000 nM
Estimate against measurement, compound 3: 2.0-fold (0.30 log units) above; measured number inside the range.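

In this assay, the hex-1-yn-1-yl chain and the methyl it replaces cannot be told apart at this aromatic carbon, two atoms from the ring nitrogen, while the methoxy and chlorine stay in place: a 1.2-fold higher number from compound 2 to compound 3 (0.09 log units; within the scatter). With the hex-1-yn-1-yl chain held constant, the comparison that does show a change beyond the scatter is methoxy in place of hydrogen on an aromatic carbon, which gives an at least 2.4-fold lower number from compound 1 to compound 3 (0.38 log units; beyond the scatter). Compound 1 enters that comparison only as a limit, so the full size of this step remains unknown: the limit of > 36300 nM in this assay, at which 1 of the 3 values shown sits.

The compounds shown do not tell whether a propyl chain, an amine or a carboxylic acid at this position would also leave the number within the scatter of compound 2. Within the data shown here, they also leave open whether swapping methyl for hex-1-yn-1-yl would look the same on a core without the methoxy, as no pair shows that change in that setting.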